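From an Acetamido Group to a Hydroxy Group

The source may hold more compounds than are shown below. What is called first, only, known or untested is meant among the compounds shown, and "the series" means these compounds.

Of the compounds shown here, three built on one shared core have been tested in a functional assay on the whole organism with Rattus norvegicus as the target, at a dose of 40 mg/kg by the intraperitoneal route; a lower number here means less inhibition, a higher number more inhibition at the dose given (going by the name of the read-out). Compound 1 `Cc1nc2c(CCc3ccccc3)cccn2c1N` gives 47%. Compound 2 `Cc1nc2ccc(CCc3ccccc3)cn2c1N` gives 52%. Compound 3 `CC(=O)Nc1c(C)nc2c(CCc3ccccc3)cccn12` gives 40%, which is the lowest of the three numbers; its distance to compound 1 is the step of a number 7 percentage points lower from compound 1 to compound 3 (within the scatter) and lies within the scatter, while its gap to compound 2 lies beyond the scatter.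

Compound 4 `Cc1nc2c(CCc3ccccc3)cccn2c1O` has not yet been measured. It differs from compound 3 in one place: hydroxy in place of acetamido on an aromatic carbon. Among the compounds with values here, only one measured step touches the same spot, namely a number 7 percentage points lower from compound 1 to compound 3 (within the scatter), in which an acetyl replaced a hydrogen on a nitrogen on an aromatic ring, and that step stayed within the scatter. Within the data shown here, no measured compound carries a hydroxy at this position, so the effect of the hydroxy group itself is untested, and the step to compound 4 must be judged from that single neighbouring step alone.

Given that the one related step of a number 7 percentage points lower from compound 1 to compound 3 (within the scatter) was small, I expect the step of a number 5 percentage points higher from compound 3 to compound 4 (within the scatter) to be modest and not clearly beyond the scatter. For compound 4 in this assay I therefore estimate 45%, with a range from 25% to 65%.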

Compound 4, a percentage reported as inhibition, in the whole organism at one dose (the size of the read-out at that dose, not a potency): 32%
The estimate for compound 4 lay 13 percentage points above the measured number; the range from low to high includes it.
By their numbers in this assay, from the lowest: compounds 4, 3, 1 and 2 (each within the scatter of the next, the first and the last beyond it).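

In this assay, putting hydroxy in place of acetamido on this aromatic carbon gives a number 8 percentage points lower from compound 3 to compound 4 (within the scatter), so on its own this exchange does not separate the two groups, even though the whole acetamido group is replaced. Within the data shown here, the comparison with the free amino group says more: hydroxy in place of amino gives a number 15 percentage points lower from compound 1 to compound 4 (beyond the scatter), and this is the first step at this position that passes beyond the scatter, which shows that the group on this carbon can change the read-out at the dose given. Nothing measured on these compounds accounts for that step.

From the compounds shown here alone, it remains open whether the amino group stands out here or the hydroxy group does, and a methoxy group, a carboxylic acid or a longer chain on the same carbon would help to settle that. Going by these compounds, it is also open whether hydroxy in place of amino would have a similar effect on the core of compound 2, and since each number comes from a single dose, none of them shows how potency differs between the compounds.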